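Swapping an acetamidomethyl arm for a piperidine amide

The compounds below may be only part of what the source reports. "The series", "measured", "known", "first", "only" and "open" are said of these compounds alone.

Compound 1 `COc1ccc(-c2nc(CNC(C)=O)sc2-c2ccc(OC)cc2)cc1` is the anchor of this small set. Going by the values given here, in a functional assay with Oryctolagus cuniculus as the target (a lower number here means a stronger inhibitor, a higher number a weaker inhibitor), compound 1 gives 15 nM, the only firm number among the two values recorded. Compound 2 `COc1ccc(-c2nc(CNC(=O)CSc3ccccc3)sc2-c2ccc(OC)cc2)cc1` carries phenylsulfanyl in place of hydrogen on a saturated chain carbon bound to a carbonyl carbon; in this assay compound 2 is recorded only as a limit, < 100 nM. The step that the limit leaves unreadable from compound 1 to compound 2 therefore cannot be sized, as the limit of < 100 nM in this assay, at which 1 of the 2 values shown sits, states.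

Compound 3 `COc1ccc(-c2nc(C(=O)N3CCCCC3)sc2-c2ccc(OC)cc2)cc1` changes a different part of the shared core: (piperidin-1-yl)carbonyl in place of acetamidomethyl on an aromatic carbon. Among the compounds with values here, no measured step touches this aromatic carbon, so the one recorded step offers no guide, and the expectation rests on compound 1 alone. Compound 3 is estimated at 40 nM, within a range from 6 nM to 300 nM. That estimate means an expected step of a 2.7-fold higher number from compound 1 to compound 3 (0.43 log units; beyond the scatter), close to the usual scatter.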

Compound 3, half-maximal inhibitory concentration: > 1000 nM
Compound 3 was reported as a limit (the forecaster's own chance of this, stated with the estimate: 25%); at least 25-fold (1.39 log units) between middle value and limit.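

Going by these compounds alone, this change at the aromatic carbon, which no earlier step touched, produces a large loss of inhibition in this assay, with an at least 66-fold higher number from compound 1 to compound 3 (1.82 log units; beyond the scatter). The size of this step is not exact, since compound 3 is recorded only as a limit: the limit of > 1000 nM in this assay, at which 1 of the 3 values shown sits. So compound 1 shows that acetamidomethyl suits this position, whereas compound 3 shows that the position does not tolerate every amide-containing group, even though both groups carry a carbonyl.

From the compounds shown here alone, the swap makes several changes at once: it adds a six-membered ring, goes from 1 hydrogen-bond donor to 0, and attaches the carbonyl directly to the aromatic carbon, so which of these matters remains open. A primary carboxamide or a piperidin-1-ylmethyl group at this aromatic carbon would help to separate these changes.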